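The compounds below may be only part of what the source reports. "The series", "measured", "known", "first", "only" and "open" are said of these compounds alone.

In a functional assay on LoVo cells (Homo sapiens) for cytotoxicity, read by MTT assay (a lower number here means a stronger inhibitor, a higher number a weaker inhibitor), compound 1 `Oc1ccc(CN(Cc2ccccc2)Cc2ccc(O)c3ncccc23)c2cccnc12` gives 91 nM and compound 2 `Oc1ccc(CN(Cc2ccccc2C(F)(F)F)Cc2ccc(O)c3ncccc23)c2cccnc12` gives 93 nM. These two sit level, while compound 3 `Oc1ccc(CN(Cc2cccc(I)c2)Cc2ccc(O)c3ncccc23)c2cccnc12` gives 393 nM, so compound 1 shares the low end of this small set with compound 2.

Compound 4 `O=C(O)C1CCC(CN(Cc2ccc(O)c3ncccc23)Cc2ccc(O)c3ncccc23)CC1` keeps the shared core but changes one arm: 4-carboxycyclohexyl in place of phenyl on a saturated chain carbon bound to an amine nitrogen.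

Among the measured compounds shown here, two measured steps bear on this, and both alter the phenyl that compound 4 gives up. Trifluoromethyl gives a 1.0-fold higher number from compound 1 to compound 2 (0.01 log units; within the scatter), and iodo gives a 4.3-fold higher number from compound 1 to compound 3 (0.64 log units; beyond the scatter). Neither removes the phenyl or brings in a carboxy group, so these steps are only a loose guide. The replacement in compound 4 is a larger structural change than either of them. Compound 3, with its step of a 4.3-fold higher number from compound 1 to compound 3 (0.64 log units; beyond the scatter), shows that a change on this arm can raise the number, so a modest rise in this assay is expected, with wide uncertainty.

The estimated step is a 3.8-fold higher number from compound 1 to compound 4 (0.59 log units; beyond the scatter).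

For compound 4 the expected value is 350 nM, within an estimated range of 100 nM to 1500 nM.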

Compound 4, half-maximal inhibitory concentration: 422 nM
Estimate against measurement, compound 4: 1.2-fold (0.08 log units) below; low and high end bracket the measured number.
By their numbers in this assay, from the lowest: compounds 1 and 2 (each within the scatter of the next); then compounds 3 and 4 (each within the scatter of the next).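

Among the compounds shown here, until now every change on this arm kept an aromatic ring, and compound 4 is the first to replace it with a non-aromatic ring carrying a carboxy group. In this assay this replacement gives a 4.6-fold higher number from compound 1 to compound 4 (0.67 log units; beyond the scatter) and also a 4.5-fold higher number from compound 2 to compound 4 (0.66 log units; beyond the scatter) but only a 1.1-fold higher number from compound 3 to compound 4 (0.03 log units; within the scatter) so a far larger change to the arm lands level with adding a single iodo group. Nothing measured here accounts for this rise.

Compound 4 loses the aromatic ring and gains the carboxy group in one move, and the compounds shown do not separate those two changes. As far as these compounds go, a plain cyclohexyl arm or a phenyl carrying a carboxylic acid would tell them apart, and an amine in place of the carboxylic acid also remains open.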